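The source may hold more compounds than are shown below. What is called first, only, known or untested is meant among the compounds shown, and "the series" means these compounds.

Measured so far:
- compound 1 `Cc1ccc(S(=O)(=O)Nc2ccc3ncc(-c4cnn(C)c4)cc3n2)cc1`, in a functional assay on HeLa cells (Homo sapiens) for antiproliferative activity, read by MTT assay, with a stated time of 48 h; on this read-out lower numbers stand for stronger inhibition and higher numbers for weaker inhibition: > 50000 nM, a limit of the assay
- compound 2 `Cn1cc(-c2cnc3ccc(NS(=O)(=O)c4cccs4)nc3c2)cn1`, in this assay: 38400 nM
- compound 3 `Cc1ccc(S(=O)(=O)Nc2nccc3ncc(-c4cnn(C)c4)cc23)cc1`, in this assay: > 50000 nM, a limit of the assay

Compound 1 and compound 3 share the same atoms joined differently; the difference between the two cores is not broken down here. For compound 1 only a limit is known in this assay, and for compound 3 the same holds, so neither can be placed against the other.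

Within the first core, the change thiophen-2-yl in place of 4-methylphenyl on a sulfonyl sulfur gives an at least 1.3-fold lower number from compound 1 to compound 2 (0.11 log units; that floor lies within the scatter). Among the measured compounds shown here, because the starting point is the limit of > 50000 nM in this assay, at which 2 of the 3 values shown sit, the real size of that step is not known; only that compound 2 returns a number while compound 1 does not.

Compound 4 `Cn1cc(-c2cnc3ccnc(NS(=O)(=O)c4cccs4)c3c2)cn1` is not yet measured. It carries the same change, (thiophen-2-yl in place of 4-methylphenyl on a sulfonyl sulfur), on the core of compound 3. The two place lines read the same word for word, so this is the same change, now on a core that in this assay also sits at the limit for compound 3.

Compound 4 is expected to give 42000 nM in this assay, with a range of 18000 nM to 100000 nM. For the measured compounds named here, that rests on the one measured example: the step from compound 1 to compound 2 with an at least 1.3-fold lower number from compound 1 to compound 2 (0.11 log units; that floor lies within the scatter) was small, so from compound 3 the expected step is an at least 1.1-fold lower number from compound 3 to compound 4 (0.07 log units; that floor lies within the scatter), leaving compound 4 close to the limit, as likely to be reported as a limit as as a number.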

Compound 4, half-maximal inhibitory concentration: 17400 nM
Beside the measured number, compound 4's estimate is 2.4-fold (0.38 log units) above it, outside the stated range (below it).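

In this assay, thiophen-2-yl in place of 4-methylphenyl on a sulfonyl sulfur gives an at least 2.8-fold lower number from compound 3 to compound 4 (0.45 log units; beyond the scatter), so on both cores shown, the thiophen-2-yl compound returns a number where the 4-methylphenyl compound stands at a limit. This supports carrying the change across these two cores in direction only, and it does not establish that the change is worth the same on each: the same change on two cores in this assay, an at least 1.3-fold lower number (0.11 log units; that floor lies within the scatter) from compound 1 to compound 2 and an at least 2.8-fold lower number (0.45 log units; beyond the scatter) from compound 3 to compound 4; the limit leaves it open whether they differ. Among the compounds shown here, both steps are floors, so the real size of the change is unknown on either core, and each core offers only one pair, which gives no basis for extending the result to other cores: the limit of > 50000 nM in this assay, at which 2 of the 4 values shown sit.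

The compounds shown leave open whether another group on the sulfonyl sulfur, such as a longer alkyl chain, or a thiophen-2-yl carrying an amine or a carboxylic acid, would move the numbers in this assay further from the limit on either core. Also open, going by these compounds, is what a methyl group on the sulfonamide nitrogen would do to the read-out, which would show whether the hydrogen there matters.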